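An Ester Change on Compound 3 Without a Guiding Step

A few compounds are considered here, and "the series" means these few. Any claim that something is new, unique, unknown or untested is made for them only; others in the source may bear on it.

Compound 3 `CC(C)OC(=O)C(=O)Nc1cccccc1=O` stands highest of the three compounds measured in a functional assay on the whole organism (strain Sprague-Dawley CD) for inhibition, with Rattus norvegicus as the target, read by paw edema, at a dose of 100 mg/kg by the oral route; on this read-out higher numbers stand for a stronger effect at the one dose given and lower numbers for a weaker effect: compound 3 gives 72%. Compound 1 `CCOC(=O)C(=O)Nc1ccccc(C)c1=O` gives 34% in this assay, and compound 2 `CCOC(=O)C(=O)Nc1ccccc(Br)c1=O` gives 0%. Among the measured compounds shown here, the one step between measured compounds that differ in a single place, a number 34 percentage points lower from compound 1 to compound 2 (beyond the scatter), concerns bromo in place of methyl on an aromatic carbon rather than anything on the oxygen next to a carbonyl group. Compound 4 `CCOC(=O)COC(=O)C(=O)Nc1cccccc1=O` differs from compound 3 in one place: (ethoxycarbonyl)methyl in place of isopropyl on an oxygen next to a carbonyl group. For the measured compounds named here, no measured step bears on this change; compound 1 and compound 3 differ in two places at once, so their values give no separate reading of the ester side. The expectation therefore rests on the level of compound 3 alone and carries a wide range. Compound 4 is estimated at 50%, with a range from 15% to 80%. The expected step in this assay is a number 22 percentage points lower from compound 3 to compound 4 (beyond the scatter).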

Compound 4, a percentage reported as inhibition, in the whole organism at one dose (the size of the read-out at that dose, not a potency): 64%
Beside the measured number, compound 4's estimate is 14 percentage points below it; low and high end bracket the measured number.
By their numbers in this assay, from the lowest: compound 2; then compound 1; then compounds 4 and 3 (each within the scatter of the next).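

In this assay, the ester side now has a reading of its own: the step is a number 8 percentage points lower from compound 3 to compound 4 (within the scatter). On this oxygen next to a carbonyl group, (ethoxycarbonyl)methyl and isopropyl therefore cannot be told apart on this read-out, although the entering group is the larger of the two and brings an ester of its own. No measurement available here gives a reason for this result.

On these data alone, whether a carboxylic acid in place of the (ethoxycarbonyl)methyl group, or a longer plain chain such as butyl, would keep the read-out at this level remains open. Also open, as far as these compounds go, is whether methyl or bromo on an aromatic carbon of the core would have the same effect alongside either of these two ester groups.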